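Imidazopyrazine series: benzyl for cyclohexyl on the benzimidazole nitrogen

This account rests on a few compounds, and the source may have more. Where it says the series, first, only, none or still open, it means among the compounds named here.

Measured so far:
compound 1, `c1ccc(-c2cn3ccnc3c(-c3ccc4ncn(C5CCCCC5)c4c3)n2)cc1`: -11.1%
compound 2, `c1ccc(Cn2cnc3ccc(-c4nc(-c5cccc6ccccc56)cn5ccnc45)cc32)cc1`: 73.8%
compound 3, `c1cn2cc(-c3ccc4c(c3)ncn4C3CCCCC3)nc(-c3ccc4ncn(C5CCCCC5)c4c3)c2n1`: 44.7%

In a functional assay on T47D cells (Homo sapiens) for inhibition, read by sulforhodamine B assay, with a stated time of 48 h, tested at 10 uM (on this read-out lower numbers stand for less inhibition and higher numbers for more inhibition at the one concentration tested (going by the name of the read-out)), compound 3 stands second of the three. Compound 2 is the nearest number, and it lies beyond the scatter above compound 3. Compound 1 is the furthest and lies beyond the scatter below compound 3. Going by the values given here, no pair of the measured compounds differs in one place only, so no single step can be read off directly.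

Compound 4, `c1ccc(Cn2cnc3ccc(-c4nc(-c5ccc6c(c5)ncn6C5CCCCC5)cn5ccnc45)cc32)cc1`, has not yet been measured. Against compound 3 the change is benzyl in place of cyclohexyl on an aromatic nitrogen. The same benzyl group sits on the corresponding nitrogen of compound 2, the compound with the highest number; the other partner differs there, so this is a weak guide only. A step of modest size upward is expected in this assay, possibly no larger than the scatter.

For compound 4 the estimate is 55%, with a range of 25% to 80%. The expected step is a number 10.3 percentage points higher from compound 3 to compound 4 (beyond the scatter).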

Compound 4, a percentage reported as inhibition, at one concentration (the size of the read-out at that concentration, not a potency) in the T47D assay: -2.12%
Compound 4: the middle estimate sits 57.1 percentage points above what was measured, and the stated range ends above it.
By their numbers in the T47D assay, from the lowest: compounds 1 and 4 (each within the scatter of the next); then compound 3; then compound 2.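

Going by these compounds alone, in the T47D assay compound 3 gives 44.7% and compound 4 gives -2.12% and benzyl in place of cyclohexyl on an aromatic nitrogen gives a number 46.8 percentage points lower from compound 3 to compound 4 (beyond the scatter) and provides the first direct reading at this position. Inhibition here therefore depends strongly on which group sits on that nitrogen, even though neither group carries a hydrogen-bond donor, a hydrogen-bond acceptor or a net charge. In a physicochemical assay for lipophilicity, using the shake flask method, in phosphate buffer, measured as octanol-water partition, with a stated time of 85 min, at pH 7.4 (a higher number here means a more lipophilic compound, a lower number a more polar compound), compound 3 gives 1.9 and compound 4 gives 1.61 and the same change gives a number 0.29 log units lower from compound 3 to compound 4 (within the scatter) and so does not separate the two compounds on that read-out, while no measured evidence bears on the origin of the large step in inhibition.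

From the compounds shown here alone, it remains open whether a phenyl group directly on that nitrogen, a cyclopentyl group or a chain ending in an amine would retain the inhibition seen with cyclohexyl. Going by these compounds, the same change at the second cyclohexyl group of compound 3 also remains open.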